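Oxime ethers on a shared core: a methoxy on the benzyl

A few compounds are considered here, and "the series" means these few. Any claim that something is new, unique, unknown or untested is made for them only; others in the source may bear on it.

Measured so far in an assay on HepG2 cells for agonist activity at nuclear receptor subfamily 1 group I member 3 (Homo sapiens), read by a luciferase reporter, with a stated time of 23 h; a higher number here means that more compound is needed for the effect, a lower number that less compound is needed:
compound 1 `C(=N/OCc1ccccc1)\c1c(-c2ccc3ccccc3c2)nc2occn12` — 840 nM
compound 2 `Clc1ccc(CO/N=C/c2c(-c3ccc(-c4ccccc4)cc3)nc3sccn23)cc1Cl` — "not active" (no number reported)
compound 3 `Clc1ccc(-c2nc3occn3c2/C=N/OCc2ccc(Cl)c(Cl)c2)cc1` — 410 nM

Compound 1 carries the highest of the two numbers recorded in this assay. Its nearest neighbour on the numbers is compound 3, whose value 410 nM lies lower by a margin beyond the usual scatter. Compound 2 has no number at all: in this assay compound 2 is reported as "not active" (no number reported). Among the measured compounds shown here, these three compounds differ from one another in more than one place, so no single step between measured compounds can be read off.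

The next compound, compound 4 `COc1ccc(CO/N=C/c2c(-c3ccc4ccccc4c3)nc3occn23)cc1`, departs from compound 1 in one place: methoxy in place of hydrogen on an aromatic carbon. For the measured compounds named here, no measured pair shows the effect of this change, and the two numbers available give no direction for it. The change is small in size, so the step from compound 1 to compound 4 is expected to be modest, and may well fall within the scatter in either direction. The expected step is a 1.2-fold lower number from compound 1 to compound 4 (0.08 log units; within the scatter). For compound 4 the expected value in this assay is 700 nM, with a range from 250 nM to 2000 nM.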

Compound 4, half-maximal effective concentration: 4400 nM
The estimate for compound 4 lay 6.3-fold (0.80 log units) below the measured number; measured number above the stated range.
By their numbers in this assay, from the lowest: compound 3; then compound 1; then compound 4.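

Methoxy in place of hydrogen on the benzyl, para to a large group, carries a clear cost in this assay: a 5.2-fold higher number from compound 1 to compound 4 (0.72 log units; beyond the scatter). Among the compounds shown here, this is the first step that can be read at a single place, and it shows that this position responds to substitution rather than being indifferent to it. The finding rests on one pair on the core of compound 1, and nothing at hand explains the direction or size of the step.

Going by these compounds, whether the loss belongs to methoxy in particular or to any group at this carbon remains open; a fluorine, an amine or a longer chain such as ethoxy in the same place would help to separate the two. Also open, on these data alone, is whether the same change gives a similar step on a different core.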